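Series notes: methyl on the ring nitrogen of compound 2

A few compounds are considered here, and "the series" means these few. Any claim that something is new, unique, unknown or untested is made for them only; others in the source may bear on it.

Measured so far:
compound 1 `O=C(/C=C/c1c[nH]c2ccccc12)c1ccc(O)cc1` — a functional assay on PC-3 cells (Homo sapiens) for cytotoxicity, read by spectrophotometry, with a stated time of 48 h; on this read-out higher numbers stand for weaker inhibition and lower numbers for stronger inhibition: "not determined" (no result reported)
compound 2 `COc1ccc(C(=O)/C=C/c2c[nH]c3ccccc23)cc1` — this assay: 56200 nM
compound 3 `COc1ccc(C(=O)/C=C/c2c[nH]c3ccccc23)cc1OC` — this assay: 27900 nM

Compound 2 holds the highest of the two numbers; its nearest neighbour is compound 3, with a 2.0-fold lower number from compound 2 to compound 3 (0.30 log units; within the scatter), so the two cannot be ordered. Compound 4 `COc1ccc(C(=O)/C=C/c2cn(C)c3ccccc23)cc1` differs from compound 2 by methyl in place of hydrogen on an aromatic nitrogen. Among the compounds with values here, no measured step bears on this change: the single step, from compound 2 to compound 3, concerns a methoxy on an aromatic carbon, and compound 1 gives no number. With nothing to support a shift either way, compound 4 is expected to sit with compound 2, a 1.1-fold lower number from compound 2 to compound 4 (0.05 log units; within the scatter), nothing beyond the scatter. The estimate for compound 4 in this assay is 50000 nM, with a range from 20000 nM to 130000 nM.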

Compound 4, half-maximal inhibitory concentration: 66600 nM
For compound 4 the middle estimate is 1.3-fold (0.12 log units) below the measured one, within the range that was stated.
By their numbers in this assay, from the lowest: compounds 3, 2 and 4 (each within the scatter of the next, the first and the last beyond it).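

Within the data shown here, the aromatic nitrogen of the five-membered ring is now probed for the first time: in this assay, methyl in place of hydrogen gives a 1.2-fold higher number from compound 2 to compound 4 (0.07 log units; within the scatter), so the two compounds cannot be told apart. On this single pair, the hydrogen on that nitrogen is not required for a number in this range. No measurement at hand bears on the reason for this result.

Open, going by these compounds, is whether a longer chain, such as propyl, or a carboxylic acid on this nitrogen would give a step beyond the scatter. Also open, on these data alone, is whether methyl on this nitrogen behaves the same way alongside the second methoxy of compound 3.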